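The source may report more compounds than this note shows. Statements on the series, on what has been measured and on what is new or still open speak of the compounds shown alone.

Working notes on the series. Compound 1 `C=C1C(=O)[C@]23C[C@@]1(O)CC[C@H]2c1ccc(OS(=O)(=O)c2ccc(C)cc2)c(C)c1[C@@H]3Cn1cc(-c2ccc(C)cc2)nn1`, compound 2 `C=C1C(=O)[C@]23C[C@@]1(O)CC[C@H]2c1ccc(OS(=O)(=O)c2ccc(C)cc2)c(C)c1[C@@H]3Cn1cc(-c2ccc(F)cc2)nn1` and compound 3 `C=C1C(=O)[C@]23C[C@@]1(O)CC[C@H]2c1ccc(OS(=O)(=O)c2ccc(C)cc2)c(C)c1[C@@H]3Cn1cc(-c2ccc(OC)cc2)nn1` share one core and differ only in the group on a single aromatic carbon of the outer phenyl ring. In a functional assay on SW480 cells (Homo sapiens) for cytotoxicity, read by MTT assay, with a stated time of 4 days (a lower number here means a stronger inhibitor, a higher number a weaker inhibitor), compound 1 gives 1460 nM. In this assay compound 2 gives 1630 nM, and compound 3 gives 1640 nM. The three measured steps are a 1.1-fold higher number from compound 1 to compound 2 (0.05 log units; within the scatter), a 1.1-fold higher number from compound 1 to compound 3 (0.05 log units; within the scatter) and a 1.0-fold higher number from compound 2 to compound 3 (0.00 log units; within the scatter). Compound 3 holds the highest number of the three, yet each gap to the other two lies within the scatter, so no order among compounds 1, 2 and 3 can be read from these numbers.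

Compound 4 `C=C1C(=O)[C@]23C[C@@]1(O)CC[C@H]2c1ccc(OS(=O)(=O)c2ccc(C)cc2)c(C)c1[C@@H]3Cn1cc(-c2ccc(Cl)cc2)nn1` is the next member: chloro in place of methoxy on an aromatic carbon. Within the data shown here, the steps that bear on this change are those at the same aromatic carbon, a 1.0-fold higher number from compound 2 to compound 3 (0.00 log units; within the scatter), where one single-atom halogen was exchanged for the methoxy that now leaves, and a 1.1-fold higher number from compound 1 to compound 3 (0.05 log units; within the scatter); both were within the scatter. Nothing among the three measured compounds shows a shift at this position beyond the scatter, so for compound 4 the step of a 1.0-fold lower number from compound 3 to compound 4 (0.01 log units; within the scatter) is expected to stay within the scatter in this assay. Compound 4 is therefore estimated at 1600 nM, with a range from 900 nM to 2900 nM.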

Compound 4, half-maximal inhibitory concentration: 2390 nM
Compound 4: middle estimate off by 1.5-fold (0.17 log units), on the low side; the range from low to high includes it.
By their numbers in this assay, from the lowest: compounds 1, 2, 3 and 4 (each within the scatter of the next).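

Replacing the 4-methoxyphenyl with a 4-chlorophenyl gives the widest steps yet seen at this aromatic carbon in this assay (a 1.5-fold higher number from compound 3 to compound 4 (0.16 log units; within the scatter)) (a 1.5-fold higher number from compound 2 to compound 4 (0.17 log units; within the scatter)) (a 1.6-fold higher number from compound 1 to compound 4 (0.21 log units; within the scatter)), wider than any step among compounds 1, 2 and 3, yet each of them still lies within the scatter. Methyl, fluoro, methoxy and chloro have now all been seen at this one carbon without any pair of them separating beyond the scatter, so this small set tolerates the exchange in this assay and gives no order among compounds 1, 2, 3 and 4. No supporting measurement on these compounds bears on the wider steps to compound 4, and they may be no more than ordinary assay variation.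

Open, going by these compounds, is whether any group at this carbon can move the number beyond the scatter, since a basic amine, a carboxylic acid, a hydroxyl or a longer alkyl chain would test it more sharply than these four. Also open, on these data alone, is whether the same flat picture holds with the rest of the shared core changed, for example with the sulfonate ester replaced by a free phenol.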